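A few compounds are considered here, and "the series" means these few. Any claim that something is new, unique, unknown or untested is made for them only; others in the source may bear on it.

Measured compounds:
- Compound 1 `CSc1ncnc2c1c(-c1ccccc1)cn2[C@@H]1O[C@H](CO)[C@@H](O)[C@H]1O`: > 20000 nM, a limit of the assay
- Compound 2 `COc1nc(N)nc2c1c(-c1ccco1)cn2[C@@H]1O[C@H](CO)[C@@H](O)[C@H]1O`: > 20000 nM, a limit of the assay
- Compound 3 `Nc1nc2c(c(-c3cccs3)cn2[C@@H]2O[C@H](CO)[C@@H](O)[C@H]2O)c(=O)[nH]1`: 16800 nM

All three compounds were tested in a functional assay on K562 cells (Homo sapiens), read by MTT assay, with a stated time of 72 h; a higher number here means a weaker inhibitor, a lower number a stronger inhibitor. Compound 3, at 16800 nM, is the only one of them with an actual number. The other two results are limits, as shown by the limit of > 20000 nM in this assay, at which 2 of the 3 values shown sit. Compound 4 `Nc1nc2c(c(-c3cc4ccccc4o3)cn2[C@@H]2O[C@H](CO)[C@@H](O)[C@H]2O)c(=O)[nH]1` keeps the core of compound 3 and differs from it as follows: 1-benzofuran-2-yl in place of thiophen-2-yl on an aromatic carbon. In words, it has 1-benzofuran-2-yl in place of thiophen-2-yl on an aromatic carbon.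

Among the compounds with values here, no two measured compounds differ in one place only, so the data offer no step to carry over. In this assay, a change no larger than the scatter is therefore expected, with neither direction favoured. The expected change, a 1.1-fold higher number from compound 3 to compound 4 (0.03 log units; within the scatter), rests on the value of compound 3 at 16800 nM. For compound 4 the estimated value is 18000 nM, with an expected range of 7000 nM to 30000 nM.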

Compound 4, half-maximal inhibitory concentration: > 20000 nM
Compound 4 gave a limit, no number; the forecaster's own chance of this, stated with the estimate: 55%; middle value at least 1.1-fold (0.04 log units) from the limit.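

In this assay compound 4 gives > 20000 nM, which is a limit of the assay and not a number. On these data alone, putting 1-benzofuran-2-yl in place of thiophen-2-yl on this aromatic carbon amounts to an at least 1.1-fold higher number from compound 3 to compound 4 (0.07 log units; that floor lies within the scatter), so the step gives only a floor within the scatter and its true size stays unknown. The change adds a six-membered aromatic ring of carbon only at this place, yet the result gives no second number on this core and joins the others at the same end of the assay: the limit of > 20000 nM in this assay, at which 3 of the 4 values shown sit.

The compounds shown leave open whether any group on this aromatic carbon can give a number well clear of that limit. A methyl or an aminomethyl group there, on the core of compound 3, would test whether the position responds at all.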